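From chloro to methoxymethoxy on a shared core

A few compounds are considered here, and "the series" means these few. Any claim that something is new, unique, unknown or untested is made for them only; others in the source may bear on it.

Measured in a functional assay on SMMC-7721 cells (Homo sapiens) for antiproliferative activity, read by MTT assay, with a stated time of 48 h; a lower number here means a stronger inhibitor, a higher number a weaker inhibitor:
Compound 1 `COC/C1=C/C[C@](C)(CCC=C(C)C)/C=C/[C@@H](OC(=O)C=C(C)C)[C@](C)(OC)/C=C/C1=O` gives 9380 nM
Compound 2 `CC(C)=CCC[C@]1(C)/C=C/[C@@H](OC(=O)C=C(C)C)[C@](C)(O)/C=C/C(=O)/C(CCl)=C\C1` gives 840 nM
Compound 3 `CC(C)=CCC[C@]1(C)/C=C/[C@@H](OC(=O)C=C(C)C)[C@](C)(O)/C=C/C(=O)/C(C[Si](c2ccccc2)(c2ccccc2)C(C)(C)C)=C\C1` gives 38000 nM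

Compound 2 stands lowest of the three, and it is the strongest inhibitor here, since the gaps from it to compound 1 and to compound 3 both lie beyond the scatter. Compound 4 (`COCOC/C1=C/C[C@](C)(CCC=C(C)C)/C=C/[C@@H](OC(=O)C=C(C)C)[C@](C)(O)/C=C/C1=O`) has yet to be measured. It departs from compound 2 in one place: methoxymethoxy in place of chloro on a saturated chain carbon bound to a double-bonded ring carbon. Among the compounds with values here, no measured pair isolates a change of this kind. Still, compound 1 at 9380 nM and compound 3 at 38000 nM both lack the chloro and both sit higher than compound 2, so a move towards a weaker inhibitor, beyond the scatter, is expected in this assay. The expected change is a 7.1-fold higher number from compound 2 to compound 4 (0.85 log units; beyond the scatter) as estimated here. For compound 4 the estimated value is 6000 nM, with an expected range from 2000 nM to 18000 nM.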

Compound 4, half-maximal inhibitory concentration: 3250 nM
The estimate for compound 4 lay 1.8-fold (0.27 log units) above the measured number; the measured number falls inside the stated range.
By their numbers in this assay, from the lowest: compound 2; then compound 4; then compound 1; then compound 3.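

Placing methoxymethoxy in place of chloro on a saturated chain carbon bound to a double-bonded ring carbon gives a 3.9-fold higher number from compound 2 to compound 4 (0.59 log units; beyond the scatter) in this assay, the first reading of a single change at this position. Within the data shown here, the change is modest, and compound 4 still gives 3250 nM with four heavy atoms in place of one, so chloro is not the only group here that leaves measurable activity, although compound 2 remains the strongest of the four. No measurement shown explains the rise in the number.

The two groups cannot separate the number of heavy atoms from the presence of oxygen. From the compounds shown here alone, whether a hydroxy group, an amine or bromo on this carbon would stand nearer to compound 2 or to compound 4 remains open.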